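Bromo in place of fluoro: compound 3 to compound 4

This account rests on a few compounds, and the source may have more. Where it says the series, first, only, none or still open, it means among the compounds named here.

Compound 1 `COc1ccccc1Oc1c(N)nc(-c2ccccc2)nc1OCCO` gives > 80000 nM in a functional assay on A-375 cells (Homo sapiens) for cytotoxicity, read by CCK-8 assay, with a stated time of 24 h (on this read-out higher numbers stand for weaker inhibition and lower numbers for stronger inhibition), which is a limit of the assay and not a number. Compound 2 `COc1ccccc1Oc1c(N)nc(-c2ccc(C)cc2)nc1OCCO` gives 2380 nM. Compound 3 `COc1ccccc1Oc1c(N)nc(-c2cccc(F)c2)nc1OCCO` gives 8530 nM, the higher of the two true numbers. Compound 4 `COc1ccccc1Oc1c(N)nc(-c2cccc(Br)c2)nc1OCCO` carries bromo in place of fluoro on an aromatic carbon, meta to a large group (bromo in place of fluoro on an aromatic carbon). Bearing on this are an at least 33-fold lower number from compound 1 to compound 2 (1.52 log units; beyond the scatter) and an at least 9.3-fold lower number from compound 1 to compound 3 (0.97 log units; beyond the scatter), both towards lower numbers, and the modest 3.6-fold higher number from compound 2 to compound 3 (0.55 log units; beyond the scatter). Within the data shown here, no measured step exchanges one halogen for another. A modest step towards a lower number is expected, estimated as a 1.9-fold lower number from compound 3 to compound 4 (0.28 log units; within the scatter). The estimate for compound 4 is 4500 nM, with an expected range of 1300 nM to 14000 nM.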

Compound 4, half-maximal inhibitory concentration: 650 nM
Compound 4: the middle estimate sits 6.9-fold (0.84 log units) above what was measured, outside the stated range (below it).
By their numbers in this assay, from the lowest: compound 4; then compound 2; then compound 3. At a limit, above all of these: compound 1.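

Exchanging one halogen for another on this aromatic carbon gives a 13-fold lower number from compound 3 to compound 4 (1.12 log units; beyond the scatter) as a large step, so the two halogens are not interchangeable here. The 3-bromophenyl also moves past the 4-methylphenyl, with a 3.7-fold lower number from compound 2 to compound 4 (0.56 log units; beyond the scatter) and the lowest number in the series. The step of an at least 120-fold lower number from compound 1 to compound 4 (2.09 log units; beyond the scatter) rests on a limit of the assay for compound 1, not on a number: the limit of > 80000 nM in this assay, at which 1 of the 4 values shown sits.

As far as these compounds go, whether 3-chlorophenyl or 3-iodophenyl would continue this halogen order stays open, as does whether bromo keeps its advantage as 4-bromophenyl. From the compounds shown here alone, what an amine or a nitrile at this place would give also stays open.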